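A few compounds are considered here, and "the series" means these few. Any claim that something is new, unique, unknown or untested is made for them only; others in the source may bear on it.

Measured so far in a functional assay on OVCAR-3 cells (Homo sapiens) for inhibition, read by sulforhodamine B assay, with a stated time of 48 h, tested at 0.01 uM; a lower number here means a stronger effect, a higher number a weaker effect of the compound at the concentration tested:
- compound 1 `O=C(Nc1cccc(-n2cc(-c3ccncc3)c(-c3cc(O)cc(Cl)c3)n2)c1)Nc1ccc(Cl)c(C(F)(F)F)c1`: 101%
- compound 2 `O=C(Nc1cccc(-n2cc(-c3ccncc3)c(-c3cc(O)cc(Cl)c3)n2)c1)Nc1ccc(Cl)c(Cl)c1`: 103%
- compound 3 `COc1cc(Cl)cc(-c2nn(-c3cccc(NC(=O)Nc4ccc(Cl)c(Cl)c4)c3)cc2-c2ccncc2)c1`: 100%

All three numbers sit at the top of the scale, so none of the compounds shows an effect at this concentration. Compound 3 carries the lowest of the three numbers, but its neighbours are close: compound 1 is nearest, compound 2 furthest, and both gaps lie within the scatter. The two measured steps confirm this: a number 2 percentage points higher from compound 1 to compound 2 (within the scatter) and a number 3 percentage points lower from compound 2 to compound 3 (within the scatter) are both within the scatter.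

Compound 4 `COc1cc(Cl)cc(-c2nn(-c3cccc(NC(=O)c4cccc(C(F)(F)F)c4)c3)cc2-c2ccncc2)c1` differs from compound 3 at the carbonyl carbon whose other neighbour is the amide-type nitrogen: 3-(trifluoromethyl)phenyl in place of (3,4-dichlorophenyl)amino on a carbonyl carbon. Within the data shown here, neither measured step touches this part of the molecule, so no step bears directly on the change; what the series shows is only that every variation tried so far left the read-out unchanged. Compound 4 is therefore expected to stay near the others, with no change at the digits printed from compound 3 to compound 4 (within the scatter) as the estimated step. The estimate for compound 4 in this assay is 100%, ranging from 88% to 112%.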

Compound 4, a percentage reported as activity, at one concentration (the size of the read-out at that concentration, not a potency): 105%
The estimate for compound 4 lay 5 percentage points below the measured number; the range from low to high includes it.
By their numbers in this assay, from the lowest: compounds 3, 1, 2 and 4 (each within the scatter of the next).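

In this assay, among these compounds, the position on the carbonyl carbon, which no earlier step touched, gives a read-out that stays at the top of the scale: 3-(trifluoromethyl)phenyl in place of (3,4-dichlorophenyl)amino gives a number 5 percentage points higher from compound 3 to compound 4 (within the scatter). The change exchanges a group with a hydrogen-bond donor for one without, and it also replaces the two chlorine atoms with three fluorine atoms, yet compound 4 shows no effect at this concentration, so the step cannot rank the two groups. Nothing at hand accounts for this flat result.

From the compounds shown here alone, whether a morpholine or a cyclohexylamino group on the same carbonyl carbon would move the read-out off the top of the scale stays open. Also open, going by these compounds, is whether compound 3 and compound 4 separate at a higher concentration.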